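The source may hold more compounds than are shown below. What is called first, only, known or untested is meant among the compounds shown, and "the series" means these compounds.

Measured so far in a functional assay on the whole organism with Rattus norvegicus as the target, at a dose of 100 mg/kg; a lower number here means less inhibition, a higher number more inhibition at the dose given (going by the name of the read-out):
compound 1 `C/N=C(/NC#N)NCCCn1nc(-c2ccccc2)ccc1=O`: 40.5%
compound 2 `N/C(S)=N/CCCCn1nc(-c2ccccc2)ccc1=O`: 72%

Compound 1 stands lowest of the two; the change to compound 2 gives a number 31.5 percentage points higher from compound 1 to compound 2 (beyond the scatter), and that step alters the chain end, not the ring.

Compound 3 `C/N=C(/NC#N)NCCCn1nc(C)ccc1=O` differs from compound 1 by methyl in place of phenyl on an aromatic carbon. No measured step touches this ring position, so nothing shown bears directly on it. Going by the values given here, with only the step to compound 2 as a guide to the spread of this assay, compound 3 is expected to land near or somewhat under compound 1, a change estimated at a number 8.5 percentage points lower from compound 1 to compound 3 (within the scatter). Compound 3 is thus estimated at 32%, in the range 10% to 55%.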

Compound 3, a percentage reported as inhibition, in the whole organism at one dose (the size of the read-out at that dose, not a potency): 6.8%
Estimate against measurement, compound 3: 25.2 percentage points above; the measured number lies below the stated range.
By their numbers in this assay, from the lowest: compound 3; then compound 1; then compound 2.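

The aromatic carbon bearing phenyl in compound 1 proves to be a sensitive position in this assay: methyl in place of phenyl gives a number 33.7 percentage points lower from compound 1 to compound 3 (beyond the scatter). The number at this dose therefore depends on this ring position as well as on the chain end. No measurement at hand explains the step.

From the compounds shown here alone, whether a benzyl or an ethyl group at this carbon would keep the number stays open. So does how the chain end of compound 2 would behave with methyl in place of phenyl.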